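This account rests on a few compounds, and the source may have more. Where it says the series, first, only, none or still open, it means among the compounds named here.

Compound 1 `CCc1cccc2c(OC)c(-c3occ(C)c3CO)ccc12` gives 7.1 ug/mL in a functional assay on KB cells (Homo sapiens) for cytotoxicity, read by MTT assay, with a stated time of 72 h; on this read-out lower numbers stand for an effect already at smaller amounts and higher numbers for an effect only at larger amounts of compound. Compound 2 `CCOc1c(-c2occ(C)c2CO)ccc2c(CC)cccc12` reaches only a limit of the assay there, > 10 ug/mL. Compound 3 `CCc1cccc2c(OC)c(-c3occ(C)c3COC)ccc12` likewise reaches only a limit, > 10 ug/mL. The change from compound 1 to compound 2 is methyl in place of hydrogen on a saturated chain carbon bound to an oxygen on an aromatic ring, and it brings an at least 1.4-fold higher number from compound 1 to compound 2 (0.14 log units; that floor lies within the scatter). Compound 1 and compound 3 differ by methyl in place of hydrogen on an oxygen on a saturated carbon, giving an at least 1.4-fold higher number from compound 1 to compound 3 (0.14 log units; that floor lies within the scatter); both steps end at the limit of > 10 ug/mL in this assay, at which 2 of the 3 values shown sit. Compound 4 `CCOc1c(-c2occ(C)c2COC)ccc2c(CC)cccc12` has not yet been measured. It differs from compound 3 by methyl in place of hydrogen on a saturated chain carbon bound to an oxygen on an aromatic ring, the same change, at the same place, as that from compound 1 to compound 2. Since compound 2 showed an at least 1.4-fold higher number from compound 1 to compound 2 (0.14 log units; that floor lies within the scatter) for this change, a comparable shift is expected again, namely a step that the limit leaves unreadable from compound 3 to compound 4 in this assay. Compound 4 is therefore estimated at 20 ug/mL in this assay, most probably reported once more only as a limit.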

Compound 4, concentration for half-maximal effect: > 10 ug/mL
Compound 4 gave a limit, no number; the forecaster's own chance of this, stated with the estimate: 85%; the middle value does not contradict the limit.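

No new step can be read for compound 4 against compound 2 or compound 3 in this assay, as all three end at the same limit: the limit of > 10 ug/mL in this assay, at which 3 of the 4 values shown sit.

The compounds shown leave open how far compound 2, compound 3 and compound 4 actually lie from one another.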